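From Ethyl to Methoxy on an Aromatic Ring

The source may hold more compounds than are shown below. What is called first, only, known or untested is meant among the compounds shown, and "the series" means these compounds.

Measured in a functional assay on Jurkat cells (Homo sapiens) for inhibition, read by CCK-8 assay, with a stated time of 48 h; on this read-out higher numbers stand for weaker inhibition of growth and lower numbers for stronger inhibition of growth:
Compound 1 `CN1CCN(c2ccc(Nc3ncc(Cl)c(NCc4ccccc4)n3)nc2)CC1`: > 100000 nM, a limit of the assay and not a number
Compound 2 `Cc1ccc(CNc2nc(Nc3ccc(N4CCN(C)CC4)cn3)ncc2Cl)cc1`: 12700 nM
Compound 3 `CCc1ccc(Nc2nc(Nc3ccc(N4CCN(C)CC4)cn3)ncc2Cl)cc1`: 11100 nM

Compound 3 gives 11100 nM, level within the scatter with compound 2 at 12700 nM. Compound 4 `COc1ccc(Nc2nc(Nc3ccc(N4CCN(C)CC4)cn3)ncc2Cl)cc1` differs from it in one group: methoxy in place of ethyl on an aromatic carbon. This puts methoxy in place of ethyl on an aromatic carbon, para to a large group. Among the measured compounds shown here, no measured step makes this exact swap. The closest guide is a 1.1-fold lower number from compound 2 to compound 3 (0.06 log units; within the scatter), a change of the same aromatic part that stayed within the scatter. Another is an at least 7.8-fold lower number from compound 1 to compound 2 (0.89 log units; beyond the scatter), which came with a single methyl on an aromatic carbon and was at least modest. The expected result is a 1.4-fold higher number from compound 3 to compound 4 (0.13 log units; within the scatter), a small step with no firm direction. Compound 4 is estimated at 15000 nM, with a range of 5000 nM to 50000 nM.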

Compound 4, concentration for 50% growth inhibition: 11200 nM
Compound 4: the middle estimate sits 1.3-fold (0.13 log units) above what was measured; the range from low to high includes it.
By their numbers in this assay, from the lowest: compounds 3, 4 and 2 (each within the scatter of the next). At a limit, above all of these: compound 1.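

In this assay, methoxy brings a hydrogen-bond acceptor to this aromatic carbon, para to a large group, where ethyl has none, yet the swap gives a 1.0-fold higher number from compound 3 to compound 4 (0.00 log units; within the scatter). With methoxy in place, the comparison with the benzyl-linked series also stays level, at a 1.1-fold lower number from compound 2 to compound 4 (0.05 log units; within the scatter). The remaining step, an at least 8.9-fold lower number from compound 1 to compound 4 (0.95 log units; beyond the scatter), starts from a limit and not a number: the limit of > 100000 nM in this assay, at which 1 of the 4 values shown sits.

On these data alone, what an amine, a carboxylic acid or a longer chain would give at this carbon stays open. So does whether methoxy would read the same on the benzyl group of compound 1.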